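The compounds below may be only part of what the source reports. "The series", "measured", "known", "first", "only" and "open" are said of these compounds alone.

The measured compounds are:

compound 1, `COc1ccc(/C=C(\C)C(=O)/C=C/c2ccc(Br)cc2)cc1`, with 31200 nM in an ADME assay on Vero cells (Chlorocebus sabaeus) for cytotoxicity, read by MTT assay, with a stated time of 72 h; on this read-out lower numbers stand for higher toxicity in this test and higher numbers for lower toxicity in this test

compound 2, `CC/C(=C\c1ccc(Cl)cc1)C(=O)/C=C/c1cccc(OC)c1OC`, with 21800 nM in this assay

Going by the values given here, only two compounds have a number in this assay so far. Compound 1 gives 31200 nM there, and compound 2 gives 21800 nM; the two numbers lie within the usual scatter of each other, so nothing can be said about an order between them. Among the compounds with values here, no pair among the measured compounds differs in only one place, so no measured step is available to lean on.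

Compound 3, `COc1ccc(/C=C(\C)C(=O)/C=C/c2ccccc2Br)cc1`, is not yet measured. It is built from the same atoms as compound 1, joined differently: 2-bromophenyl in place of 4-bromophenyl on a double-bonded chain carbon bound to a double-bonded chain carbon. Within the data shown here, with no comparable step in hand, the expectation rests on the structural change alone. Compound 3 is expected to stay close to compound 1, with a step of a 1.1-fold lower number from compound 1 to compound 3 (0.05 log units; within the scatter) that does not go beyond the scatter in either direction. For compound 3 the estimated number in this assay is 28000 nM, with a range from 14000 nM to 56000 nM.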

Compound 3, half-maximal cytotoxic concentration: 71000 nM
For compound 3 the middle estimate is 2.5-fold (0.40 log units) below the measured one; the whole stated range lies below it.
By their numbers in this assay, from the lowest: compounds 2 and 1 (each within the scatter of the next); then compound 3.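

Going by these compounds alone, with the same atoms joined differently, 2-bromophenyl in place of 4-bromophenyl on a double-bonded chain carbon bound to a double-bonded chain carbon gives, in this assay, a 2.3-fold higher number from compound 1 to compound 3 (0.36 log units; beyond the scatter), the first step in this small set that stands clear of the usual scatter. This shows that where the bromine sits on this phenyl ring can by itself shift the read-out, modestly and towards lower toxicity in this test, something that compounds 1 and 2 could not show, as they differ in more than one place and their numbers lie within the scatter of each other. No measurement is at hand that would account for this shift, so the step stands as an observation for this one pair alone.

The compounds shown leave open whether the same exchange would give a step of similar size and direction on the core of compound 2, where a chlorine rather than a bromine sits on the phenyl ring. They also leave open how the read-out would respond if the bromine on this ring gave way to a different group altogether, such as a nitrile, an amine or a carboxylic acid.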